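Adding a 4-Chlorophenyl to Compound 1

The source may report more compounds than this note shows. Statements on the series, on what has been measured and on what is new or still open speak of the compounds shown alone.

Compound 1 `Nc1ncnn2c([C@@H]3O[C@H](CO)[C@@H](O)[C@H]3O)ccc12` was tested in an ADME assay on cells (Macrophage, Mus musculus) for cytotoxicity; a lower number here means that less compound is tolerated, a higher number that more compound is tolerated. In this assay compound 1 gives < 250 nM, which is a limit of the assay and not a number. Compound 1 therefore stands at the limit of < 250 nM in this assay, at which 1 of the 3 values shown sits. Compound 2 `Nc1ncnc2c([C@@H]3O[C@H](CO)[C@@H](O)[C@H]3O)cn(-c3ccc(Cl)c(F)c3)c12` gives > 64000 nM in this assay, again a limit. Compound 3 `Nc1nccn2c([C@@H]3O[C@H](CO)C[C@H]3O)cnc12` gives > 64000 nM in this assay, also a limit. These two compounds sit at the limit of > 64000 nM in this assay, at which 2 of the 3 values shown sit. Among the measured compounds shown here, no step between measured compounds that differ in a single place exists here, so the three values show only that compound 1 is tolerated far less than compound 2 and compound 3, with the size of that gap unknown.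

Compound 4 `Nc1ncnn2c([C@@H]3O[C@H](CO)[C@@H](O)[C@H]3O)cc(-c3ccc(Cl)cc3)c12` has not yet been measured. It differs from compound 1 by 4-chlorophenyl in place of hydrogen on an aromatic carbon. For the measured compounds named here, compound 2 also carries an aromatic ring on its core and sits at the upper limit, but its core differs from that of compound 1 in more than one place, so no step can be drawn from it. The step from compound 1 to compound 4 is expected to be an at least 32-fold higher number from compound 1 to compound 4 (1.50 log units; beyond the scatter), toward greater tolerance. Compound 4 is estimated at 8000 nM in this assay, between 800 nM and 64000 nM.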

Compound 4, half-maximal cytotoxic concentration: 5000 nM
For compound 4 the middle estimate is 1.6-fold (0.20 log units) above the measured one, and the stated range covers the measured number.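

The carbon two ring bonds from the ring nitrogen, on the five-membered aromatic ring, accepts a large aromatic group, and that single change moves the read-out in this assay: the 4-chlorophenyl in place of hydrogen gives an at least 20-fold higher number from compound 1 to compound 4 (1.30 log units; beyond the scatter), beyond the scatter and the only step shown that can be read within one core. On these data alone, compound 1 gives < 250 nM, which is a limit of the assay and not a number, so this step fixes only a minimum size and the true size stays unknown: the limit of < 250 nM in this assay, at which 1 of the 4 values shown sits. Compound 4 gives a number and not a limit, so on this core the change lands at a value that can be measured in this assay, away from the crowded upper end: the limit of > 64000 nM in this assay, at which 2 of the 4 values shown sit.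

The compounds shown leave open whether the step belongs to the chlorine or to the ring itself, as a plain phenyl at this carbon would tell. They also leave open whether an amine, a carboxylic acid or a longer chain on the same carbon would move the number in the same direction or by a similar amount.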